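Aryl variation on the piperidine nitrogen of the shared core

A few compounds are considered here, and "the series" means these few. Any claim that something is new, unique, unknown or untested is made for them only; others in the source may bear on it.

Three compounds share one core and differ only in the aryl group on the ring nitrogen. Compound 1 `O=C1COc2ccc(NC(=O)C3CCN(c4ccccc4Br)CC3)cc2N1` gives 71 nM in an assay on HEK293 cells for displacement of a labelled ligand from transient receptor potential cation channel subfamily V member 1 (Homo sapiens); a lower number here means a stronger inhibitor, a higher number a weaker inhibitor; compound 2 `Cc1ccccc1N1CCC(C(=O)Nc2ccc3c(c2)NC(=O)CO3)CC1` gives 61 nM; compound 3 `O=C1COc2ccc(NC(=O)C3CCN(c4cc(F)c(F)c(F)c4)CC3)cc2N1` gives 49 nM, the lowest of the three numbers, though the gaps to the others are within the scatter. Compound 4 `Cc1cccc(N2CCC(C(=O)Nc3ccc4c(c3)NC(=O)CO4)CC2)c1C` carries 2,3-dimethylphenyl in place of 3,4,5-trifluorophenyl on an amine nitrogen in a ring. The steps of a 1.4-fold lower number from compound 1 to compound 3 (0.16 log units; within the scatter) and a 1.2-fold lower number from compound 2 to compound 3 (0.10 log units; within the scatter) bear on this change, and both stayed within the scatter. No step beyond the scatter is therefore expected in this assay. Compound 4 is expected at 60 nM, with a range of 25 nM to 150 nM, amounting to the estimated step of a 1.2-fold higher number from compound 3 to compound 4 (0.09 log units; within the scatter).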

Compound 4, inhibition constant: 28 nM
Compound 4: middle estimate off by 2.1-fold (0.33 log units), on the high side; the measured number falls inside the stated range.
By their numbers in this assay, from the lowest: compounds 4, 3, 2 and 1 (each within the scatter of the next, the first and the last beyond it).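

Adding methyl to the aromatic ring of the group on the piperidine nitrogen gives the first change in this series beyond the scatter in this assay (a 2.2-fold lower number from compound 2 to compound 4 (0.34 log units; beyond the scatter)). The 2,3-dimethylphenyl group also separates from 2-bromophenyl (a 2.5-fold lower number from compound 1 to compound 4 (0.40 log units; beyond the scatter)), but not from 3,4,5-trifluorophenyl (a 1.8-fold lower number from compound 3 to compound 4 (0.24 log units; within the scatter)). No supporting measurement accounts for these steps.

On these data alone, whether the gain follows the two methyl groups themselves remains open, and 2,3-dichlorophenyl or 2,3-dimethoxyphenyl would test this. As far as these compounds go, a pyridine ring on this nitrogen also remains untested in these compounds.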